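Trading a triazole for a methyl ester on the sulfur-linked chain

This account rests on a few compounds, and the source may have more. Where it says the series, first, only, none or still open, it means among the compounds named here.

Measured compounds:
- compound 1 `N#Cc1c(N)nc(SCC(N)=O)c(C#N)c1-c1ccc(OCC2CC2)cc1`: 31%
- compound 2 `N#Cc1c(N)nc(SCn2cncn2)c(C#N)c1-c1ccc(OCC2CC2)cc1`: 12%

Both compounds share one core and differ only in the group carried on a saturated chain carbon bound to a sulfur. In an assay on CHO cells for displacement of a labelled ligand from adenosine receptor A1 (Homo sapiens), read by scintillation counting, with a stated time of 90 min, tested at 1 uM (on this read-out higher numbers stand for more inhibition at the one concentration tested (going by the name of the read-out) and lower numbers for less inhibition), compound 1 gives 31%, and compound 2 gives 12%. Going by the values given here, the single measured step, a number 19 percentage points lower from compound 1 to compound 2 (beyond the scatter), places compound 2 at the lower of the two numbers, with compound 1 the only neighbour and standing higher by more than the usual scatter.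

Compound 3 `COC(=O)CSc1nc(N)c(C#N)c(-c2ccc(OCC3CC3)cc2)c1C#N` has not yet been measured. It differs from compound 2 as follows: methoxycarbonyl in place of 1H-1,2,4-triazol-1-yl on a saturated chain carbon bound to a sulfur. Among the compounds with values here, the one step that bears on this change is a number 19 percentage points lower from compound 1 to compound 2 (beyond the scatter), which removed a carbamoyl and brought in the triazole. Compound 3 now removes that triazole and brings in a group that, like the carbamoyl of compound 1, carries a carbonyl and no ring. A partial return toward the number of compound 1 is therefore expected, though the two groups are not identical and the size of any rise is uncertain.

For compound 3 a modest upward step is expected, a number 12 percentage points higher from compound 2 to compound 3 (beyond the scatter), giving an estimated 24% with a range from 8% to 42%.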

Compound 3, a percentage reported as inhibition, at one concentration (the size of the read-out at that concentration, not a potency): 23%
Beside the measured number, compound 3's estimate is 1 percentage points above it, within the range that was stated.
By their numbers in this assay, from the lowest: compound 2; then compounds 3 and 1 (each within the scatter of the next).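

In this assay, putting methoxycarbonyl where the 1H-1,2,4-triazol-1-yl stood gives a number 11 percentage points higher from compound 2 to compound 3 (beyond the scatter), which shows that the lower reading with the triazole can be reversed at this position, at least in part, by a group with a carbonyl and no ring. On the carbonyl carbon itself, methoxy in place of amino gives a number 8 percentage points lower from compound 1 to compound 3 (within the scatter), so this assay does not separate the carbamoyl and methoxycarbonyl groups, and among these three compounds only compound 2 stands apart from the others. Nothing available explains why the triazole compound reads differently from the two carbonyl compounds.

Going by these compounds, it remains open whether a carboxylic acid, a dimethylamino group on the carbonyl carbon or a longer chain between the sulfur and the carbonyl would keep a reading like those of the two carbonyl compounds, and whether another five-membered aromatic ring, such as an imidazole, would behave like the triazole. All of these readings also come from a single concentration, so they leave the actual potency of each compound undefined.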